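Para substituent swap on the aryl-vinyl series: propyl to tert-butoxy

The source may hold more compounds than are shown below. What is called first, only, known or untested is meant among the compounds shown, and "the series" means these compounds.

Three analogues of a shared core have been measured in an assay on membranes from brain for displacement of a labelled ligand from Neuronal acetylcholine receptor; alpha4/beta2 (Rattus norvegicus), with a stated time of 3 h; on this read-out lower numbers stand for stronger inhibition and higher numbers for weaker inhibition. Compound 1 `CCCc1ccc(/C=C2\CCCN=C2c2cccnc2)cc1` gives 890 nM in this assay. Compound 2 `COc1ccc2cc(/C=C3\CCCN=C3c3cccnc3)ccc2c1` gives 600 nM in this assay, and compound 3 `Cc1cc(C)c(/C=C2\CCCN=C2c2cccnc2)c(C)c1` gives 520 nM in this assay. Among the measured compounds shown here, of the three numbers, the one for compound 1 is the highest, but its gap to compound 2 and its gap to compound 3 both fall within the usual scatter of repeated measurements, so the three compounds cannot be separated on these data.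

Compound 4 `CC(C)(C)Oc1ccc(/C=C2\CCCN=C2c2cccnc2)cc1` has not yet been measured in this assay. It differs from compound 1 in one place: tert-butoxy in place of propyl on an aromatic carbon. The tert-butoxy group sits on an aromatic carbon of a six-membered aromatic ring of carbon only, para to a large group, where compound 1 carries propyl.

For the measured compounds named here, no step between measured compounds bears on this particular exchange, so no direction can be read from the series. Given that every number so far sits in a narrow band, compound 4 is expected to stay near compound 1, with a step of a 1.2-fold lower number from compound 1 to compound 4 (0.07 log units; within the scatter) that is not expected to exceed the scatter in either direction. On that basis the estimate for compound 4 in this assay is 750 nM, within a range from 250 nM to 2200 nM.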

Compound 4, inhibition constant: 2170 nM
Compound 4: middle estimate off by 2.9-fold (0.46 log units), on the low side; the range from low to high includes it.
By their numbers in this assay, from the lowest: compounds 3, 2 and 1 (each within the scatter of the next); then compound 4.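

In this assay, the aromatic carbon para to a large group proves sensitive to what it carries: tert-butoxy in place of propyl gives a 2.4-fold higher number from compound 1 to compound 4 (0.39 log units; beyond the scatter), a modest step but the only one read so far in the series, and it lies beyond the scatter. The exchange raises the count from 3 heavy atoms to 5 and brings in one oxygen and one hydrogen-bond acceptor, all within a single change, so this pair cannot show which of these differences goes with the higher number. Nothing on hand accounts for the step.

On these data alone, whether the higher number follows the oxygen or the tert-butyl shape of the group stays open, and a straight propoxy chain or a tert-butyl group carried directly on the same aromatic carbon would pull these two apart. Also open, as far as these compounds go, is whether any group at this place, such as an amine or a carboxylic acid, would move the number the other way from compound 1.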